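Saturating the chain end of compound 1

The source may report more compounds than this note shows. Statements on the series, on what has been measured and on what is new or still open speak of the compounds shown alone.

Measured so far in a functional assay, read by fluorescence and spectrophotometry, with a stated time of 1 h (on this read-out higher numbers stand for an effect only at larger amounts of compound and lower numbers for an effect already at smaller amounts), for this series:
- compound 1 `C=CCCCCCCS(=O)(=O)/C=C/c1ccc(O)c(O)c1` gives 6400 nM
- compound 2 `O=S(=O)(/C=C/c1ccc(O)c(O)c1)CC1CCCN1` gives 13800 nM
- compound 3 `O=S(=O)(/C=C/c1ccc(O)c(O)c1)CC1CCCCO1` gives 10800 nM

Compound 1 stands apart from compound 2 only, with the lower number of that pair, and it cannot be separated from compound 3 on these data. Compound 2 and compound 3 also remain unresolved, since a 1.3-fold lower number from compound 2 to compound 3 (0.11 log units; within the scatter) stays within the scatter.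

Next is compound 4 `CCCCCCCCCS(=O)(=O)/C=C/c1ccc(O)c(O)c1` and its difference from compound 1 is propyl in place of vinyl on a saturated chain carbon, six bonds along the chain from a sulfonyl sulfur. Among the compounds with values here, no measured step tests this change directly. The nearest evidence is the replacement of the whole hept-6-en-1-yl, which gave only a 2.2-fold higher number from compound 1 to compound 2 (0.33 log units; beyond the scatter) with pyrrolidin-2-yl and a 1.7-fold higher number from compound 1 to compound 3 (0.23 log units; within the scatter) with oxan-2-yl. A change confined to the chain end is therefore expected to produce no step beyond the scatter in this assay and no clear direction. The expected step, a 1.1-fold lower number from compound 1 to compound 4 (0.03 log units; within the scatter) in this estimate, is small. For compound 4 the estimated value is 6000 nM with an expected range from 3000 nM to 12000 nM as its limits.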

Compound 4, half-maximal effective concentration: 7700 nM
Beside the measured number, compound 4's estimate is 1.3-fold (0.11 log units) below it; the range from low to high includes it.
By their numbers in this assay, from the lowest: compounds 1, 4, 3 and 2 (each within the scatter of the next, the first and the last beyond it).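

In this assay, within the data shown here, the swap of vinyl for propyl on a saturated chain carbon, six bonds along the chain from a sulfonyl sulfur, gives a 1.2-fold higher number from compound 1 to compound 4 (0.08 log units; within the scatter), the first reading confined to this position rather than a replacement of the whole hept-6-en-1-yl. The double bond outside aromatic rings that vinyl carries is therefore not required to hold the number in this range, since the pair cannot be separated with or without it, and the position accepts propyl with no step beyond the scatter. Nothing available explains this tolerance or links it to any property of either group.

One saturated group and one unsaturated group at this position say little about how far the tolerance extends, and an amine, a carboxylic acid or a hydroxyl on this chain carbon could behave quite differently from propyl. As far as these compounds go, whether a longer chain or a much shorter one, such as ethyl in place of the whole hept-6-en-1-yl, stays within the scatter of compound 1 also remains open.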